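The compounds below may be only part of what the source reports. "The series", "measured", "known", "first", "only" and "open" are said of these compounds alone.

Compound 1 `C/C(=C\CC/C(C)=C/CC[C@@H]1[C@@]2(C)CCC(=O)C(C)(C)[C@H]2CC[C@@]1(C)O)CC/C=C(\C)C(=O)OCc1cn(-c2ccc([N+](=O)[O-])cc2)nn1`: > 150000 nM
Compound 2 `C/C(=C\CC/C(C)=C/CC[C@@H]1[C@@]2(C)CCC(=O)C(C)(C)[C@H]2CC[C@@]1(C)O)CC/C=C(\C)C(=O)OCc1cn(-c2ccccc2Br)nn1`: > 150000 nM

The read-out here is an ADME assay on L132 cells (Homo sapiens) for cytotoxicity, read by MTT assay, with a stated time of 48 h; on this read-out lower numbers stand for stronger inhibition and higher numbers for weaker inhibition. In this assay compound 2 gives > 150000 nM, which is a limit of the assay and not a number. Compound 1 also gives only a limit, > 150000 nM. Taken together, the data so far amount to the limit of > 150000 nM in this assay, at which 2 of the 2 values shown sit.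

The next analogue, compound 3 `C/C(=C\CC/C(C)=C/CC[C@@H]1[C@@]2(C)CCC(=O)C(C)(C)[C@H]2CC[C@@]1(C)O)CC/C=C(\C)C(=O)OCc1cn(-c2ccc(F)c(Cl)c2)nn1`, keeps the shared core and the triazole-free description of nothing else changes: it carries 3-chloro-4-fluorophenyl in place of 2-bromophenyl on an aromatic nitrogen.

Within the data shown here, only one measured step bears on this change, another exchange of the group at that same place: a step that the two limits leave unreadable from compound 1 to compound 2. That step has no readable size, so it offers no measured effect to carry over. Since compound 1 and compound 2 both rest at the limit, compound 3 is expected to stay there too, with no step beyond the scatter and no direction to predict. The expected change is a number no higher from compound 2 to compound 3 (the limit leaves the size open). For compound 3 the estimated value is 150000 nM, with an expected range from 90000 nM to 300000 nM.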

Compound 3, half-maximal inhibitory concentration: > 150000 nM
Compound 3 ended at the assay's limit; the forecaster's own chance of this, stated with the estimate: 85%; the middle value lies on the limit itself.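

Compound 3 joins compound 1 and compound 2 at the limit: the limit of > 150000 nM in this assay, at which 3 of the 3 values shown sit.

Among these compounds, no step between compound 1, compound 2 and compound 3 can be read from these limits in this assay. Going by these compounds, what stays open is whether the 4-nitrophenyl, 2-bromophenyl and 3-chloro-4-fluorophenyl groups differ at all in this read-out, since each value is only a limit.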